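Trimethoxy chalcone series: removing the aryl methoxy group

The source may hold more compounds than are shown below. What is called first, only, known or untested is meant among the compounds shown, and "the series" means these compounds.

Measured so far in a functional assay on Caco-2 cells (Homo sapiens), read by fluorescence and BrdU incorporation, with a stated time of 48 h, tested at 25 uM; on this read-out higher numbers stand for a weaker effect at the one concentration tested and lower numbers for a stronger effect:
- compound 1, `COc1cc(O)c(C(=O)/C=C/c2ccc(F)cc2)c(OC)c1`: 30%
- compound 2, `COc1cc(OC)c(C(=O)/C=C/c2ccccc2SC)c(OC)c1`: 2.2%
- compound 3, `COc1cccc(/C=C/C(=O)c2c(OC)cc(OC)cc2OC)c1`: 6%

Compound 3 stands second highest of the three numbers in this assay. Its nearest neighbour is compound 2, whose number lies within the scatter of it; compound 1 is furthest, beyond the scatter. Among the measured compounds shown here, the one step that touches the aryl ring, a number 3.8 percentage points higher from compound 2 to compound 3 (within the scatter), exchanged the whole substituted ring and stayed within the scatter.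

Compound 4, `COc1cc(OC)c(C(=O)/C=C/c2ccccc2)c(OC)c1`, is the next step: hydrogen in place of methoxy on an aromatic carbon. For the measured compounds named here, no measured step isolates this change. Because a number 3.8 percentage points higher from compound 2 to compound 3 (within the scatter) was small even for a larger swap on the same ring, the expectation for compound 4 in this assay is a step of about no change at the digits printed from compound 3 to compound 4 (within the scatter), none beyond the scatter. Compound 4 is therefore estimated at 6%, in the range 1% to 20%.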

Compound 4, a percentage reported as activity, at one concentration (the size of the read-out at that concentration, not a potency): 24%
Beside the measured number, compound 4's estimate is 18 percentage points below it; the whole stated range lies below it.
By their numbers in this assay, from the lowest: compounds 2 and 3 (each within the scatter of the next); then compounds 4 and 1 (each within the scatter of the next).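

In this assay, removing the methoxy meta to a large group gives a number 18 percentage points higher from compound 3 to compound 4 (beyond the scatter) and so a weaker effect at the one concentration tested, which shows that this substituent is not dispensable. Removing methylsulfanyl gives a number 21.8 percentage points higher from compound 2 to compound 4 (beyond the scatter) in the same direction, so compound 4, with the plain phenyl, stands apart from both substituted rings. No evidence on hand explains this change.

Still open, on these data alone, is whether an amine or a carboxylic acid at this place would match methoxy or resemble hydrogen. As far as these compounds go, whether the methoxy matters only at this ring place also remains open.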